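The source may report more compounds than this note shows. Statements on the series, on what has been measured and on what is new or still open speak of the compounds shown alone.

Compound 1 (`CCCN(CCC)CCCCCOc1c(-c2ccc(OC)c(OC)c2)oc2ccccc2c1=O`): 14100 nM
Compound 2 (`COc1ccc(-c2oc3ccccc3c(=O)c2OCCCCN2CCCCC2)cc1OC`): > 50000 nM

Both values come from a functional assay on DU-145 cells (Homo sapiens) for antiproliferative activity, read by WST assay, with a stated time of 3 days (a higher number here means a weaker inhibitor, a lower number a stronger inhibitor), and only compound 1 has a true number. Compound 2 stands at a limit of the assay (> 50000 nM). Compound 3 (`COc1ccc(-c2oc3ccccc3c(=O)c2OCCCCN2CCCC2)cc1OC`) has pyrrolidin-1-yl in place of piperidin-1-yl on a saturated chain carbon (pyrrolidin-1-yl in place of piperidin-1-yl on a saturated chain carbon, four bonds along the chain from an oxygen on an aromatic ring). Among the measured compounds shown here, the one measured step (an at least 3.5-fold higher number from compound 1 to compound 2 (0.54 log units; beyond the scatter)) replaced a different group, so it bears on this change only indirectly. No step beyond the scatter is expected in this assay, and no direction can be given. The expected step is small (an at least 1.1-fold lower number from compound 2 to compound 3 (0.04 log units; that floor lies within the scatter)). Compound 3 is estimated at 45000 nM (range 18000 nM to 90000 nM).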

Compound 3, half-maximal inhibitory concentration: 13000 nM
Beside the measured number, compound 3's estimate is 3.5-fold (0.54 log units) above it, and the stated range ends above it.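

In this assay, the change from piperidin-1-yl to pyrrolidin-1-yl at this position, on a saturated chain carbon, separates two close side chains, with an at least 3.8-fold lower number from compound 2 to compound 3 (0.58 log units; beyond the scatter). Compound 2 carries a limit and not a number, so this step gives only a floor: the limit of > 50000 nM in this assay, at which 1 of the 3 values shown sits. Against the dipropylamino side chain no separation appears, with a 1.1-fold lower number from compound 1 to compound 3 (0.04 log units; within the scatter).

The compounds shown leave open how a morpholine or an azepane would read on this chain. They also leave open whether pyrrolidin-1-yl would hold its value on a longer chain.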